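Changing the aryl group on a shared core: compound 4

A few compounds are considered here, and "the series" means these few. Any claim that something is new, unique, unknown or untested is made for them only; others in the source may bear on it.

Compounds measured so far:
- compound 1 `OC[C@H]1O[C@@H](n2cnc3c(NCc4ccccc4Br)ncnc32)[C@H](O)[C@@H]1O` — in a functional assay on G-361 cells (Homo sapiens) for antiproliferative activity, with a stated time of 72 h (on this read-out higher numbers stand for weaker inhibition and lower numbers for stronger inhibition), compound 1 gives only the limit > 166000 nM
- compound 2 `Cc1ccc(CNc2ncnc3c2ncn3[C@@H]2O[C@H](CO)[C@@H](O)[C@H]2O)cc1` — for compound 2 the result in this assay is "not determined" (no result reported)
- compound 3 `OC[C@H]1O[C@@H](n2cnc3c(NCc4ccc(F)c(F)c4F)ncnc32)[C@H](O)[C@@H]1O` — in this assay compound 3 gives only the limit > 166000 nM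

Compound 3 therefore stands at the edge of what this assay can report: its value is a limit, not a number, and no growth inhibition was seen within the tested range. The same holds for compound 1, so that (the limit of > 166000 nM in this assay, at which 2 of the 3 values shown sit). For the measured compounds named here, the one measured step that is comparable, a step that the two limits leave unreadable from compound 1 to compound 3, cannot be read, since both of its ends are limits. Compound 2 adds no number.

Compound 4 `COc1cccc(CNc2ncnc3c2ncn3[C@@H]2O[C@H](CO)[C@@H](O)[C@H]2O)c1O` differs from compound 3 in one place: 2-hydroxy-3-methoxyphenyl in place of 2,3,4-trifluorophenyl on a saturated chain carbon bound to a nitrogen on an aromatic ring. Going by the values given here, no measured step tells how a change of this kind moves the read-out in this assay, and the only neighbours of compound 4 that carry a result both sit at the limit. The expectation for compound 4 is therefore that it also shows no readable inhibition, and the step that the limit leaves unreadable from compound 3 to compound 4 is expected to be none beyond the scatter. On this basis compound 4 is estimated at 200000 nM, within 50000 nM to 1000000 nM.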

Compound 4, half-maximal inhibitory concentration: 148000 nM
The estimate for compound 4 lay 1.4-fold (0.13 log units) above the measured number; measured number inside the range.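

Compound 4 is the first compound shown that gives a number rather than a limit in this assay, at 148000 nM, so this position on the shared core can carry a group that brings the result within the range the assay can report. The change from 2,3,4-trifluorophenyl gives an at least 1.1-fold lower number from compound 3 to compound 4 (0.04 log units; that floor lies within the scatter), and the change from 2-bromophenyl gives an at least 1.1-fold lower number from compound 1 to compound 4 (0.04 log units; that floor lies within the scatter), so neither step shows that compound 4 truly inhibits more strongly than the two compounds it replaces, even though its value is readable. The series as a whole still stays at the edge of this read-out: the limit of > 166000 nM in this assay, at which 2 of the 4 values shown sit.

Going by these compounds, it remains open whether the hydroxy group or the methoxy group of compound 4 matters more for this readable value, or whether the two are needed together. On these data alone, it is also open whether an amine or a carboxylic acid on the phenyl ring, or a longer chain in place of the saturated chain carbon, would give a number clearly lower than that of compound 4.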